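A few compounds are considered here, and "the series" means these few. Any claim that something is new, unique, unknown or untested is made for them only; others in the source may bear on it.

Measured so far in a functional assay on HepG2 cells (Homo sapiens) for cytotoxicity, read by MTT assay, with a stated time of 48 h; a higher number here means a weaker inhibitor, a lower number a stronger inhibitor: compound 1, `COc1cc(/C=C/C(=O)/C=C/c2nc3cc(C)ccc3n2C)ccc1O`, gives 4200 nM; compound 2, `COc1cc(/C=C/C(=O)/C=C/c2nc3c(C)c(C)ccc3n2C)ccc1O`, gives 8500 nM; compound 3, `COc1ccc(/C=C/C(=O)/C=C/c2nc3ccccc3n2C)cc1O`, gives 2900 nM.

Compound 1 and compound 3 carry different cores, and the difference between the two cores is not broken down here; their two values lie within the usual scatter of each other, while compound 2 stands apart from compound 3 by a gap beyond it. From compound 1 to compound 2 the change is methyl in place of hydrogen on an aromatic carbon and it produced a 2.0-fold higher number from compound 1 to compound 2 (0.31 log units; beyond the scatter).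

The unmeasured compound 4, `COc1ccc(/C=C/C(=O)/C=C/c2nc3cc(C)ccc3n2C)cc1O`, differs from compound 3 by methyl in place of hydrogen on an aromatic carbon. This is the same kind of change as that from compound 1 to compound 2, but not the same: in compound 2 the methyl sits ortho to a fused ring and ortho to a methyl group, whereas in compound 4 it sits meta to a fused ring and para to a fused ring. With a single earlier example, compound 4 is expected to show a 1.6-fold higher number from compound 3 to compound 4 (0.19 log units; within the scatter), a step of roughly the same modest size in this assay, resting on a 2.0-fold higher number from compound 1 to compound 2 (0.31 log units; beyond the scatter) and on compound 3 at 2900 nM. Compound 4 is therefore estimated at 4500 nM, between 2000 nM and 10000 nM.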

Compound 4, half-maximal inhibitory concentration: 3300 nM
Compound 4: the middle estimate sits 1.4-fold (0.13 log units) above what was measured, and the stated range covers the measured number.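

In this assay, methyl in place of hydrogen on an aromatic carbon gave a 1.1-fold higher number from compound 3 to compound 4 (0.06 log units; within the scatter), a step that stays inside the usual scatter. Set beside the earlier step, the size of the change does not separate the two cores, so within this small set the step carries from one core to the other without a difference that can be resolved: the same change on two cores in this assay, a 2.0-fold higher number (0.31 log units; beyond the scatter) from compound 1 to compound 2 and a 1.1-fold higher number (0.06 log units; within the scatter) from compound 3 to compound 4, 1.8-fold (0.25 log units) apart, within the scatter of two such steps. Going by these compounds alone, this does not show that the change acts identically on both cores: each core offers only one pair, and the methyl of compound 4, meta to a fused ring and para to a fused ring, does not stand where the methyl of the earlier step stands, so the effects of core and position cannot be told apart.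

The compounds shown leave open how a group other than methyl, such as chlorine, an amine or a carboxylic acid, would behave at this place. They also leave open whether the step would hold on any core beyond these two.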